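Swapping Nitro for Chloro on the Benzoyl Ring

The compounds below may be only part of what the source reports. "The series", "measured", "known", "first", "only" and "open" are said of these compounds alone.

Compound 1 `CC(/C=N/Nc1ccc([N+](=O)[O-])cc1)=N\NC(=O)c1ccccc1N` gives 29800 nM in an ADME assay on J774 cells (Mus musculus, strain BALB/c) for cytotoxicity, read by resazurin assay, with a stated time of 72 h; a higher number here means that more compound is tolerated, a lower number that less compound is tolerated.
Compound 2 `CC(/C=N/Nc1ccc([N+](=O)[O-])cc1)=N\NC(=O)c1ccc(C(F)(F)F)cc1` gives 78700 nM in this assay.
Compound 3 `CC(/C=N/Nc1ccc([N+](=O)[O-])cc1)=N\NC(=O)c1ccc([N+](=O)[O-])cc1` sits at a limit of this assay, > 100000 nM.

Compound 3 thus stands where the assay stops counting (the limit of > 100000 nM in this assay, at which 1 of the 3 values shown sits), so only a floor is known for it. The step of an at least 3.3-fold higher number from compound 1 to compound 3 (0.52 log units; beyond the scatter) is at least modest, whereas an at least 1.2-fold higher number from compound 2 to compound 3 (0.10 log units; that floor lies within the scatter) has a floor that lies within the scatter. Compound 4 `CC(/C=N/Nc1ccc([N+](=O)[O-])cc1)=N\NC(=O)c1ccc(Cl)cc1` differs from compound 3 by chloro in place of nitro on an aromatic carbon, para to a large group; this touches the same position as the change from trifluoromethyl to nitro. Since that earlier step was small at its floor, no step beyond the scatter is expected in this assay, though a number rather than a limit may appear. Compound 4 is expected to give 70000 nM, between 30000 nM and 100000 nM. The expected step is an at least 1.4-fold lower number from compound 3 to compound 4 (0.15 log units; that floor lies within the scatter).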

Compound 4, half-maximal cytotoxic concentration: 63900 nM
Compound 4: middle estimate off by 1.1-fold (0.04 log units), on the high side; the range from low to high includes it.
By their numbers in this assay, from the lowest: compound 1; then compounds 4 and 2 (each within the scatter of the next). At a limit, above all of these: compound 3.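

At this position, chloro gives a number rather than a limit, and it cannot be told apart from trifluoromethyl in this assay (a 1.2-fold lower number from compound 2 to compound 4 (0.09 log units; within the scatter)). Placing 4-chlorophenyl where 2-aminophenyl stood gives a modest step that exceeds the scatter (a 2.1-fold higher number from compound 1 to compound 4 (0.33 log units; beyond the scatter)). The change from nitro to chloro can be read only as a floor (an at least 1.5-fold lower number from compound 3 to compound 4 (0.19 log units; that floor lies within the scatter)), and the nitro compound sits at a limit: (the limit of > 100000 nM in this assay, at which 1 of the 4 values shown sits).

Still open, going by these compounds, is how far the nitro compound's true number lies from that limit. Also open, on these data alone, is whether a carboxylic acid at this position would give a step beyond the scatter.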